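Amide substituent swap from compound 2 to compound 4

The compounds below may be only part of what the source reports. "The series", "measured", "known", "first", "only" and "open" are said of these compounds alone.

Compound 2 `Cn1cc(-c2cnc3c(-c4csc(C(=O)N[C@@H]5CCC[C@H]5N)c4)cnn3c2)cn1` gives 3 nM in an assay for inhibition of MAP/microtubule affinity-regulating kinase 3 (Homo sapiens), read by HTRF, with a stated time of 2 h (a lower number here means a stronger inhibitor, a higher number a weaker inhibitor), the lowest of the three numbers recorded. Compound 1 `Cn1cc(-c2cnc3c(-c4csc(C(=O)N[C@@H]5CCC[C@@H]5O)c4)cnn3c2)cn1` gives 43 nM and compound 3 `Cn1cc(-c2cnc3c(-c4csc(C(=O)N[C@@H]5CCCC[C@H]5O)c4)cnn3c2)cn1` gives 24 nM in this assay. Compound 4 `Cn1cc(-c2cnc3c(-c4csc(C(=O)NC(CO)C5CC5)c4)cnn3c2)cn1` carries a group of 6 heavy atoms (5 carbon, 1 oxygen; one three-membered non-aromatic ring of carbon only) in place of a group of 6 heavy atoms (5 carbon, 1 nitrogen; one five-membered non-aromatic ring of carbon only), on an amide-type nitrogen. Going by the values given here, two measured steps bear on this: a 14-fold lower number from compound 1 to compound 2 (1.16 log units; beyond the scatter) and an 8.0-fold higher number from compound 2 to compound 3 (0.90 log units; beyond the scatter), each separating the nitrogen-bearing ring of compound 2 from an oxygen-bearing group. The change to compound 4 likewise removes the nitrogen-bearing ring and brings in an oxygen-bearing group, so the number in this assay is expected to rise, by roughly a 10-fold higher number from compound 2 to compound 4 (1.00 log units; beyond the scatter), toward the values of compound 1 and compound 3. Compound 4 is therefore estimated at 30 nM, with a range of 8 nM to 120 nM.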

Compound 4, half-maximal inhibitory concentration: 9 nM
The estimate for compound 4 lay 3.3-fold (0.52 log units) above the measured number, within the range that was stated.
By their numbers in this assay, from the lowest: compound 2; then compound 4; then compounds 3 and 1 (each within the scatter of the next).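

In this assay, the oxygen-bearing group with the three-membered ring keeps a gap to the nitrogen-bearing ring (a 3.0-fold higher number from compound 2 to compound 4 (0.48 log units; beyond the scatter)), but a smaller one than either earlier oxygen-bearing group showed. Oxygen-bearing groups on the amide-type nitrogen now also separate from one another beyond the scatter (a 2.7-fold lower number from compound 3 to compound 4 (0.43 log units; beyond the scatter); a 4.8-fold lower number from compound 1 to compound 4 (0.68 log units; beyond the scatter)), so carrying oxygen does not alone fix the number. No supporting data explain these differences.

Going by these compounds, whether an amine in place of the hydroxyl in the group of compound 4 would lower the number remains open. On these data alone, the separate contributions of the cyclopropyl ring and the hydroxymethyl chain also remain open.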